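This account rests on a few compounds, and the source may have more. Where it says the series, first, only, none or still open, it means among the compounds named here.

Compound 1 `Nc1cccc(-c2csc(NC(=O)CCCCCC(=O)Nc3ccccc3N)n2)c1` gives > 30000 nM in an assay on isolated protein for inhibition of histone deacetylase 8 (Homo sapiens), read by fluorescence, with a stated time of 17 h (a lower number here means a stronger inhibitor, a higher number a weaker inhibitor), a limit.
Compound 2 `CC(=O)Nc1cccc(-c2csc(NC(=O)CCCCCC(=O)Nc3ccccc3N)n2)c1` gives > 30000 nM in this assay, a limit.

In this assay compound 1 reaches only the limit of the assay, > 30000 nM. Compound 2 likewise reports only a limit, > 30000 nM. Among the measured compounds shown here, the single measured step, a step that the two limits leave unreadable from compound 1 to compound 2, therefore cannot be read, and both values sit at the limit of > 30000 nM in this assay, at which 2 of the 2 values shown sit. Compound 3 `Nc1cccc(-c2csc(NC(=O)CCCCCC(=O)NO)n2)c1` differs from compound 1 by hydroxy in place of 2-aminophenyl on an amide-type nitrogen. For the measured compounds named here, no measured step touches this change, and compound 1 itself offers only a limit, so the expectation rests on the change alone. Compound 3 is expected to give 300 nM, within 30 nM to 3000 nM. The expected step would be an at least 100-fold lower number from compound 1 to compound 3 (2.00 log units; beyond the scatter).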

Compound 3, half-maximal inhibitory concentration: 1950 nM
The estimate for compound 3 lay 6.5-fold (0.81 log units) below the measured number; measured number inside the range.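

Hydroxy in place of 2-aminophenyl on the amide-type nitrogen gives an at least 15-fold lower number from compound 1 to compound 3 (1.18 log units; beyond the scatter). This is the first readable number in this assay, so the change at this position can move the compounds off the limit, whereas the step between compound 1 and compound 2 cannot be read: the limit of > 30000 nM in this assay, at which 2 of the 3 values shown sit.

Still open, on these data alone, is whether the acetyl group seen in compound 2 would shift the number once hydroxy is in place. As far as these compounds go, it is also open how a carboxylic acid in place of hydroxycarbamoyl, or a longer chain, would read.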